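A few compounds are considered here, and "the series" means these few. Any claim that something is new, unique, unknown or untested is made for them only; others in the source may bear on it.

Working notes on the series in an ADME assay on MDBK cells (Bos taurus) for cytotoxicity; a higher number here means that more compound is tolerated, a lower number that less compound is tolerated. Compound 1 (`Fc1cccc(Cn2ccc3nc(-c4ccccc4)nc-3c2)c1`) gives > 100000 nM here, which is a limit of the assay and not a number. Compound 2 (`c1ccc(-c2nc3ccn(Cc4ccccn4)cc-3n2)cc1`) gives > 100000 nM here, again a limit and not a number. Compound 2 thus has no numeric position, and the record so far is the limit of > 100000 nM in this assay, at which 2 of the 2 values shown sit, with nothing read beyond it.

Compound 3 (`c1ccc(-c2nc3ccn(Cc4cccnc4)cc-3n2)cc1`) keeps the atoms of compound 2 but joins them differently: pyridin-3-yl in place of pyridin-2-yl on a saturated chain carbon bound to an aromatic nitrogen is the whole change, pyridin-3-yl in place of pyridin-2-yl on a saturated chain carbon bound to an aromatic nitrogen.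

Within the data shown here, only one measured step bears on this, the replacement of 3-fluorophenyl by pyridin-2-yl at the same place. It is a step that the two limits leave unreadable from compound 1 to compound 2 and so supplies no size to carry over. No shift beyond the usual scatter is therefore expected in this assay, and no direction can be assigned. The expected change is a number no higher from compound 2 to compound 3 (the limit leaves the size open) in this estimate. Compound 3 is estimated at 100000 nM within a range of 40000 nM to 200000 nM. Its measurement may well yield only a limit.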

Compound 3, half-maximal cytotoxic concentration: > 100000 nM
Compound 3: only a limit was reported (the forecaster's own chance of this, stated with the estimate: 80%); the middle value lies on the limit itself.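

The result for compound 3 is a limit of the assay and not a number, so neither its step from compound 2 nor its step from compound 1 can be read, and the record stands at: the limit of > 100000 nM in this assay, at which 3 of the 3 values shown sit.

The compounds shown leave open how much of any of them is tolerated in this assay, and whether pyridin-2-yl, pyridin-3-yl and 3-fluorophenyl differ there at all.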